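Aryl swap on a saturated ring carbon: towards compound 3

This account rests on a few compounds, and the source may have more. Where it says the series, first, only, none or still open, it means among the compounds named here.

Compound 2 `CCCCCCCCCCCCCCCCCCNC(=O)[C@H]1CSC(c2ccc(C#N)cc2)N1` is read in a functional assay on PC-3 cells (Homo sapiens) for antiproliferative activity, read by sulforhodamine B assay (a higher number here means a weaker inhibitor, a lower number a stronger inhibitor), only as a limit, namely > 20000 nM. Compound 1 `CCCCCCCCCCCCCCCCCCNC(=O)[C@H]1CSC(C2CCCCC2)N1` likewise gives a limit, > 20000 nM. The step that the two limits leave unreadable from compound 1 to compound 2 cannot be sized, and the limit of > 20000 nM in this assay, at which 2 of the 2 values shown sit, gathers both values shown. Compound 3 `CCCCCCCCCCCCCCCCCCNC(=O)[C@H]1CSC(c2c(Cl)cccc2Cl)N1` differs from compound 2 by 2,6-dichlorophenyl in place of 4-cyanophenyl on a saturated ring carbon. Going by the values given here, the only measured step, a step that the two limits leave unreadable from compound 1 to compound 2, concerns the same ring carbon but is unreadable, so no step beyond the scatter is expected in this assay and compound 3 will probably also sit at a limit. Compound 3 is estimated at 30000 nM, range 8000 nM to 100000 nM. The step expected is a step that the limit leaves unreadable from compound 2 to compound 3.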

Compound 3, half-maximal inhibitory concentration: > 20000 nM
Compound 3: a limit, no number; the forecaster's own chance of this, stated with the estimate: 80%; the middle value is on the limit's open side.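

In this assay compound 1, compound 2 and compound 3 each give only a limit, so no step among them can be read: the limit of > 20000 nM in this assay, at which 3 of the 3 values shown sit.

The compounds shown leave open whether any group on this saturated ring carbon gives a numerical value in this assay.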